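A few compounds are considered here, and "the series" means these few. Any claim that something is new, unique, unknown or untested is made for them only; others in the source may bear on it.

In a functional assay on PC-3 cells (Homo sapiens) for inhibition, read by MTT assay, with a stated time of 72 h (on this read-out higher numbers stand for weaker inhibition and lower numbers for stronger inhibition), the three measured compounds are:
compound 1, `C#CCSc1nc(Nc2ccc(C)cc2)c2ccncc2n1`, giving 15700 nM;
compound 2, `C#CCSc1nc(Nc2ccc(Cl)cc2)c2ccncc2n1`, giving 19000 nM;
compound 3, `C#CCSc1nc(Nc2cccc(Cl)c2)c2ccncc2n1`, giving 56500 nM.

Compound 2 stands second highest of these three numbers. Its nearest neighbour is compound 1: a 1.2-fold higher number from compound 1 to compound 2 (0.08 log units; within the scatter). Its furthest is compound 3: a 3.0-fold higher number from compound 2 to compound 3 (0.47 log units; beyond the scatter).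

The next compound, compound 4, `C#CCSc1nc(Nc2ccc(OC)cc2)c2ccncc2n1`, has not yet been tested in this assay. Its change from compound 2 is methoxy in place of chloro on an aromatic carbon. For the measured compounds named here, only one measured step concerns this same position, the exchange of methyl for chloro between compound 1 and compound 2, and that step stayed within the scatter. A substituent change at this position has therefore so far moved the number very little, so in this assay no step beyond the scatter is expected from compound 2 to compound 4. Compound 4 is accordingly estimated at 17000 nM, with a range from 7000 nM to 40000 nM, which is the expected 1.1-fold lower number from compound 2 to compound 4 (0.05 log units; within the scatter).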

Compound 4, half-maximal inhibitory concentration: 15100 nM
For compound 4 the middle estimate is 1.1-fold (0.05 log units) above the measured one, within the range that was stated.
By their numbers in this assay, from the lowest: compounds 4, 1 and 2 (each within the scatter of the next); then compound 3.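

In this assay the methoxy group, which brings an oxygen and a hydrogen-bond acceptor that chloro lacks, gives a 1.3-fold lower number from compound 2 to compound 4 (0.10 log units; within the scatter) and also a 1.0-fold lower number from compound 1 to compound 4 (0.02 log units; within the scatter) on this aromatic carbon. For the compounds shown here, three different groups have now been compared at this position rather than two, and no step among compound 1, compound 2 and compound 4 goes beyond the scatter.

From the compounds shown here alone, whether an amine, a carboxylic acid or a longer chain at this position would also leave the number in the same range remains open. Nothing available here explains why these three numbers lie so close together.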